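A hydroxyphenyl swap on the shared core

This account rests on a few compounds, and the source may have more. Where it says the series, first, only, none or still open, it means among the compounds named here.

In a functional assay on A549 cells (Homo sapiens) for antiproliferative activity, read by MTT assay, with a stated time of 48 h (a lower number here means a stronger inhibitor, a higher number a weaker inhibitor), compound 1 `COc1cc(-c2cccc3nc(-c4ccccc4)oc23)cc(OC)c1OC` gives 20300 nM, compound 2 `COc1ccc(-c2nc3cccc(-c4cc(OC)c(OC)c(OC)c4)c3o2)cc1` gives 2200 nM and compound 3 `COc1cc(-c2cccc3nc(-c4cccc(O)c4)oc23)cc(OC)c1OC` gives 2000 nM. Compound 3 cannot be told apart from compound 2, as the gap between them is a 1.1-fold lower number from compound 2 to compound 3 (0.04 log units; within the scatter). Both lie well under compound 1.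

Compound 4 `COc1cc(-c2nc3cccc(-c4cc(OC)c(OC)c(OC)c4)c3o2)ccc1O` keeps the core of compound 3 but carries 4-hydroxy-3-methoxyphenyl in place of 3-hydroxyphenyl, on an aromatic carbon of a five-membered aromatic ring with 1 nitrogen and 1 oxygen: 4-hydroxy-3-methoxyphenyl in place of 3-hydroxyphenyl on an aromatic carbon.

Within the data shown here, two measured steps bear on this change, and both start from compound 1. Methoxy in place of hydrogen gave a 9.2-fold lower number from compound 1 to compound 2 (0.97 log units; beyond the scatter), and hydroxy in place of hydrogen gave a 10-fold lower number from compound 1 to compound 3 (1.01 log units; beyond the scatter). Each group alone therefore came with a clear drop of similar size. Among the measured compounds shown here, compound 4 carries both groups on one ring, and no measured compound shows what the two do together. A further drop is possible, but compound 3 already holds one of the two groups, so only a small gain is expected in this assay. The expected change is a 1.3-fold lower number from compound 3 to compound 4 (0.12 log units; within the scatter). For compound 4 the estimated value is 1500 nM, with an expected range from 400 nM to 5000 nM.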

Compound 4, half-maximal inhibitory concentration: 15700 nM
Beside the measured number, compound 4's estimate is 10-fold (1.02 log units) below it; measured number above the stated range.
By their numbers in this assay, from the lowest: compounds 3 and 2 (each within the scatter of the next); then compounds 4 and 1 (each within the scatter of the next).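

In this assay, carrying both groups on one ring does not build on either group alone: 4-hydroxy-3-methoxyphenyl in place of 3-hydroxyphenyl gives a 7.9-fold higher number from compound 3 to compound 4 (0.89 log units; beyond the scatter) and in place of 4-methoxyphenyl gives a 7.1-fold higher number from compound 2 to compound 4 (0.85 log units; beyond the scatter) in this series. The clear gain that each single group brought over the plain phenyl is gone, as the remaining step is a 1.3-fold lower number from compound 1 to compound 4 (0.11 log units; within the scatter) and so cannot be told from no change at all. At this position, on an aromatic carbon next to the ring nitrogen and next to the ring oxygen, the steps of single groups on the phenyl therefore cannot simply be added to predict a ring that carries two, and nothing available here accounts for the reversal.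

The compounds shown leave open whether the loss belongs to this particular pair of groups or would follow any second group added to the ring. They also leave open how a different group, such as an amine or a carboxylic acid, would read on this ring in place of the hydroxy.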